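This account rests on a few compounds, and the source may have more. Where it says the series, first, only, none or still open, it means among the compounds named here.

In a physicochemical assay for lipophilicity, using the shake flask method, in phosphate buffer, measured as octanol-water partition, with a stated time of 30 min, at pH 7.4 (a lower number here means a more polar compound, a higher number a more lipophilic compound), three compounds sharing one core have been measured. Compound 1 `Cn1nccc1-c1cnc(NCc2c(F)ccc3c2CCO3)c2cn[nH]c(=O)c12` gives 2.6 and compound 2 `Cc1nc(CN(C)C)ccc1-c1cnc(NCc2c(F)ccc3c2CCO3)c2cn[nH]c(=O)c12` gives 2 on this scale. Compound 3 `Cc1cc(-c2cnc(NCc3c(F)ccc4c3CCO4)c3cn[nH]c(=O)c23)n(C)n1` gives 3 as the highest of the three numbers. Compound 4 `CNC(=O)c1cc(-c2cnc(NCc3c(F)ccc4c3CCO4)c3cn[nH]c(=O)c23)n(C)n1` has not yet been measured. It carries methylcarbamoyl in place of methyl on an aromatic carbon of the five-membered aromatic ring with 2 nitrogen, so that 1,3-dimethyl-1H-pyrazol-5-yl becomes 1-methyl-3-(methylcarbamoyl)-1H-pyrazol-5-yl, and the full count of that change reads methylcarbamoyl in place of methyl on an aromatic carbon here.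

The step that bears most directly is the arrival of that methyl, which gave a number 0.40 log units higher from compound 1 to compound 3 (beyond the scatter) in this series. Two larger exchanges, a number 0.60 log units lower from compound 1 to compound 2 (beyond the scatter) and a number 1.00 log units higher from compound 2 to compound 3 (beyond the scatter) here, swap the whole group on the core for 6-((dimethylamino)methyl)-2-methylpyridin-3-yl or back, so they show only how far the numbers can move among these compounds. Among the compounds with values here, no measured compound carries methylcarbamoyl, so the size of the new step rests on judgement. Losing the methyl points downward going by a number 0.40 log units higher from compound 1 to compound 3 (beyond the scatter) alone, and the entering group brings a hydrogen-bond donor and acceptor. A drop is therefore expected, with a number 0.80 log units lower from compound 3 to compound 4 (beyond the scatter) as the estimated step. For compound 4 the estimated value is 2.2 with an expected range from 1.7 to 2.7.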

Compound 4, distribution coefficient: 2.1
Estimate against measurement, compound 4: 0.10 log units above, and the stated range covers the measured number.
By their numbers in this assay, from the lowest: compounds 2 and 4 (each within the scatter of the next); then compound 1; then compound 3.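

In this assay, within the data shown here, the aromatic carbon next to the ring nitrogen had so far carried only hydrogen and methyl, and the one step known there went upward. Methylcarbamoyl in place of methyl gives a number 0.90 log units lower from compound 3 to compound 4 (beyond the scatter) and methylcarbamoyl in place of hydrogen gives a number 0.50 log units lower from compound 1 to compound 4 (beyond the scatter) so this single carbon can move the number in either direction, depending on the group it carries. The step of a number 0.10 log units higher from compound 2 to compound 4 (within the scatter) also shows that this small edit on the five-membered ring lands within the scatter of compound 2, which carries the whole 6-((dimethylamino)methyl)-2-methylpyridin-3-yl group instead, although nothing measured here explains any of these shifts.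

With a single amide at this carbon, the compounds shown cannot separate the part played by the amide hydrogen from that of the carbonyl, and a dimethylamide or a nitrile in the same place would put that question to the test. As far as these compounds go, how far the number would fall with a carboxylic acid or a hydroxymethyl group there also remains open.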